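The compounds below may be only part of what the source reports. "The series", "measured", "known", "first", "only" and "open" are said of these compounds alone.

Three analogues sharing one core have so far been run in a functional assay on HT-29 cells (Homo sapiens) for antiproliferative activity, read by sulforhodamine B assay, with a stated time of 48 h; a higher number here means a weaker inhibitor, a lower number a stronger inhibitor. Compound 1 `O=C1NCCN1c1ccc(S(=O)(=O)Nc2cccc(Br)c2)cc1` gives 77 nM. Compound 2 `COc1ccc(NS(=O)(=O)c2ccc(N3CCNC3=O)cc2)cc1` gives 800 nM. Compound 3 `O=C1NCCN1c1ccc(S(=O)(=O)Nc2ccc(Br)cc2)cc1` gives 300 nM, the second highest of the three numbers; its nearest neighbour is reached through a 2.7-fold lower number from compound 2 to compound 3 (0.43 log units; beyond the scatter) and its furthest through a 3.9-fold higher number from compound 1 to compound 3 (0.59 log units; beyond the scatter). Compound 4 `Cc1cccc(NS(=O)(=O)c2ccc(N3CCNC3=O)cc2)c1C` is not yet measured and differs from compound 3 by 2,3-dimethylphenyl in place of 4-bromophenyl on a sulfonamide nitrogen. Among the measured compounds shown here, the steps that bear on this are the earlier exchanges of the group on the sulfonamide nitrogen, a 10-fold higher number from compound 1 to compound 2 (1.02 log units; beyond the scatter) and a 3.9-fold higher number from compound 1 to compound 3 (0.59 log units; beyond the scatter), one large and one modest. For the measured compounds named here, no measured compound carries a dimethylphenyl, so the direction stays open and a shift beyond the scatter is possible either way. The expected step is a 1.2-fold lower number from compound 3 to compound 4 (0.08 log units; within the scatter). Compound 4 is estimated at 250 nM, within a range from 60 nM to 1000 nM.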

Compound 4, half-maximal inhibitory concentration: 190 nM
Compound 4: the middle estimate sits 1.3-fold (0.12 log units) above what was measured; the range from low to high includes it.
By their numbers in this assay, from the lowest: compound 1; then compounds 4 and 3 (each within the scatter of the next); then compound 2.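

A bromine on this aryl group is not required to reach the level of compound 3: the all-carbon 2,3-dimethylphenyl on the sulfonamide nitrogen gives (a 1.6-fold lower number from compound 3 to compound 4 (0.20 log units; within the scatter)). The same group does not reach the 3-bromophenyl of compound 1 (a 2.5-fold higher number from compound 1 to compound 4 (0.39 log units; beyond the scatter)), but it gives a lower number than the 4-methoxyphenyl of compound 2 (a 4.2-fold lower number from compound 2 to compound 4 (0.62 log units; beyond the scatter)). No evidence on the cause of these differences is available.

From the compounds shown here alone, whether one methyl alone would give the same result remains open. So does the effect of an amine or a carboxylic acid on this phenyl ring.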